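Swapping a Cyclohexyl Group for a Chlorofuranyl Ring

The source may report more compounds than this note shows. Statements on the series, on what has been measured and on what is new or still open speak of the compounds shown alone.

Measured so far:
Compound 1 `O=C1C[C@H](OCc2cc(-c3ccccc3)no2)[C@H]2CO[C@@H]1O2`: 9800 nM
Compound 2 `O=C1C[C@H](OCc2cc(C3CCCCC3)no2)[C@H]2CO[C@@H]1O2`: 6100 nM

Among the compounds with values here, in a functional assay on NCI-H1299 cells (Homo sapiens) for cytotoxicity, read by MTT assay, with a stated time of 48 h (on this read-out higher numbers stand for weaker inhibition and lower numbers for stronger inhibition), compound 2 gives 6100 nM, and compound 1 gives 9800 nM; the only measured step, a 1.6-fold lower number from compound 1 to compound 2 (0.21 log units; within the scatter), places the two values within the scatter of each other, so neither can be called the more potent. Compound 3 `O=C1C[C@H](OCc2cc(-c3ccc(Cl)o3)no2)[C@H]2CO[C@@H]1O2` differs from compound 2 in one place: 5-chlorofuran-2-yl in place of cyclohexyl on an aromatic carbon. Within the data shown here, the single measured step bears on this change only loosely, since it exchanged phenyl for cyclohexyl on the same aromatic carbon and moved the number by a 1.6-fold lower number from compound 1 to compound 2 (0.21 log units; within the scatter), within the scatter. Among the measured compounds shown here, with that as the sole guide, no step beyond the scatter is expected for compound 3, and the estimated step from compound 2 is a 1.1-fold higher number from compound 2 to compound 3 (0.06 log units; within the scatter). Compound 3 is therefore estimated at 7000 nM in this assay, with a range from 2500 nM to 20000 nM.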

Compound 3, half-maximal inhibitory concentration: 7600 nM
The estimate for compound 3 lay 1.1-fold (0.04 log units) below the measured number; low and high end bracket the measured number.
By their numbers in this assay, from the lowest: compounds 2, 3 and 1 (each within the scatter of the next).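

In this assay, the aromatic carbon next to the ring nitrogen has now carried three different groups, and the third leaves the number within the scatter of both others, with a 1.2-fold higher number from compound 2 to compound 3 (0.10 log units; within the scatter) and a 1.3-fold lower number from compound 1 to compound 3 (0.11 log units; within the scatter). The earlier pair compared only two hydrocarbon rings, whereas 5-chlorofuran-2-yl brings an oxygen, a chlorine and a hydrogen-bond acceptor, and still no step beyond the scatter appears among these compounds. No measured evidence is available to explain this result.

What the compounds shown leave open is whether an amine, a carboxylic acid or a longer alkyl chain on this carbon would move the number beyond the scatter. They also leave open whether changes elsewhere on the shared core would do so.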